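A few compounds are considered here, and "the series" means these few. Any claim that something is new, unique, unknown or untested is made for them only; others in the source may bear on it.

Of the compounds shown here, three sharing one core have been tested in an ADME assay on L929 cells (Mus musculus) for cytotoxicity, read by resazurin assay, with a stated time of 72 h; on this read-out lower numbers stand for stronger inhibition and higher numbers for weaker inhibition. Compound 1 `O=C(/C=C/c1ccc2c(c1)B(O)OC2)c1ccccc1O` carries a 2-hydroxyphenyl on a carbonyl carbon; in this assay compound 1 gives > 10 ug/mL, which is a limit of the assay rather than a number. Compound 3 `Cn1cccc1C(=O)/C=C/c1ccc2c(c1)B(O)OC2` has 1-methyl-1H-pyrrol-2-yl in place of 2-hydroxyphenyl on a carbonyl carbon, and in this assay compound 3 gives > 10 ug/mL, again only a limit. The step that the two limits leave unreadable from compound 1 to compound 3 therefore cannot be read from the two limits.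

Compound 2 `CSc1ccc(C(=O)/C=C/c2ccc3c(c2)B(O)OC3)cc1` is the starting point for the next step. In this assay compound 2 gives > 10 ug/mL, which is also a limit, so its standing among the values shown is a limit like the others.

Compound 4 `CC(=O)Nc1ccc(C(=O)/C=C/c2ccc3c(c2)B(O)OC3)cc1` has not yet been measured. It differs from compound 2 in one place: acetamido in place of methylsulfanyl on an aromatic carbon. Among the compounds with values here, no measured step bears directly on this change, and the limit of > 10 ug/mL in this assay, at which 3 of the 3 values shown sit, shows that every value so far sits at the same limit, so no size or direction can be drawn from them. The step that the limit leaves unreadable from compound 2 to compound 4 is therefore expected to be one that the limit hides rather than a readable change. Compound 4 is estimated at 12 ug/mL, with a range from 5 ug/mL to 30 ug/mL, and most likely the assay will again report only a limit.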

Compound 4, half-maximal inhibitory concentration: > 10 ug/mL
Compound 4 gave a limit, no number (the forecaster's own chance of this, stated with the estimate: 80%); the middle value does not contradict the limit.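

In this assay, within the data shown here, compound 4 gives > 10 ug/mL, again a limit and not a number, so no step from compound 2 to compound 4 can be read: the limit of > 10 ug/mL in this assay, at which 4 of the 4 values shown sit. The compounds shown leave open how far each one lies from that limit, and whether acetamido in place of methylsulfanyl changes the read-out at all.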